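Shortening the alkylsulfanyl chain on the shared core

The source may report more compounds than this note shows. Statements on the series, on what has been measured and on what is new or still open speak of the compounds shown alone.

Three compounds of the series have been run in a functional assay on the whole organism for activation, with Mus musculus as the target; on this read-out lower numbers stand for an effect already at smaller amounts and higher numbers for an effect only at larger amounts of compound. Compound 1 `Cc1nc(N)c2nc(O)n(Cc3ccccc3)c2n1` gives 3 mg/kg, compound 2 `CCCSc1nc(N)c2nc(O)n(Cc3ccccc3)c2n1` gives 0.1 mg/kg and compound 3 `CCCCSc1nc(N)c2nc(O)n(Cc3ccccc3)c2n1` gives 0.3 mg/kg. Compound 2 thus stands lowest of the three numbers, and both of its steps from the others are beyond the scatter: a 30-fold lower number from compound 1 to compound 2 (1.48 log units; beyond the scatter) and a 3.0-fold higher number from compound 2 to compound 3 (0.48 log units; beyond the scatter). The butylsulfanyl compound 3 also improves on compound 1, a 10-fold lower number from compound 1 to compound 3 (1.00 log units; beyond the scatter), but less than compound 2 does.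

Compound 4 `CSc1nc(N)c2nc(O)n(Cc3ccccc3)c2n1` is the next step from compound 2: hydrogen in place of ethyl on a saturated chain carbon bound to a sulfur, which cut one bond further out reads propylsulfanyl to methylsulfanyl. The measured steps bearing on this are a 3.0-fold higher number from compound 2 to compound 3 (0.48 log units; beyond the scatter), where one more chain carbon raised the number, and the pair of steps from compound 1, in which the propyl chain gave the larger gain. Chain length on the sulfur therefore matters within this set, but no measured compound tells whether a chain shorter than propyl continues the gain seen from compound 3 to compound 2 or loses it. A modest step in either direction is possible; the expected step is a 3.0-fold higher number from compound 2 to compound 4 (0.48 log units; beyond the scatter). For compound 4 the estimate in this assay is 0.3 mg/kg, within 0.07 mg/kg to 1.2 mg/kg.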

Compound 4, minimum effective dose: 0.1 mg/kg
The estimate for compound 4 lay 3.0-fold (0.48 log units) above the measured number, within the range that was stated.
By their numbers in this assay, from the lowest: compounds 2 and 4 (each within the scatter of the next); then compound 3; then compound 1.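

In this assay, shortening propylsulfanyl to methylsulfanyl leaves the number unchanged within the scatter (no change at the digits printed from compound 2 to compound 4 (within the scatter)), so on the sulfur this change shows no loss. The gain over the methyl group of compound 1 is already complete with methylsulfanyl (a 30-fold lower number from compound 1 to compound 4 (1.48 log units; beyond the scatter)), and within the three sulfur chains only butylsulfanyl stands apart (a 3.0-fold lower number from compound 3 to compound 4 (0.48 log units; beyond the scatter)), which makes compound 3 the exception to a flat response to chain length. No measurement at hand gives a reason for these steps.

On these data alone, whether the sulfur itself is needed remains open, as a methoxy or methylamino group in place of methylsulfanyl would test, and so does whether chains longer than butylsulfanyl raise the number further. As far as these compounds go, the benzyl group is constant throughout, so the effect of replacing it, for example with cyclohexylmethyl, also remains open.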